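The compounds below may be only part of what the source reports. "The series", "measured", "known", "first", "only" and "open" are said of these compounds alone.

Compound 1 `O=C1Nc2ccccc2/C1=C\c1c(Cl)n(Cc2ccccc2)c2ccccc12` was tested in a functional assay on cells (Cancer cell lines, Homo sapiens) for cytotoxicity, with a stated time of 48 h (a higher number here means a weaker inhibitor of growth, a lower number a stronger inhibitor of growth), and gave 66100 nM, the higher of the two values recorded so far. Compound 2 `COc1cc2c(/C=C3/C(=O)Nc4cccc(Cl)c43)c(Cl)n(Cc3cc(OC)c(OC)c(OC)c3)c2cc1C` gave 22900 nM in this assay; the two values lie apart by more than the usual scatter, yet compound 2 differs from compound 1 in several places at once, so no single structural change can be tied to that gap. Compound 3 `O=C1Nc2ccccc2/C1=C\c1c(Cl)n(CCCc2ccccc2)c2ccccc12` differs from compound 1 in one place only: phenethyl in place of phenyl on a saturated chain carbon bound to an aromatic nitrogen. For the measured compounds named here, no measured pair shows this kind of chain lengthening on the ring nitrogen, so nothing firm can be expected of it; the step of a 1.3-fold lower number from compound 1 to compound 3 (0.12 log units; within the scatter) is estimated to be small and, if anything, toward a lower number, but within the scatter. Compound 3 is therefore expected to give about 50000 nM, with a likely range from 18000 nM to 150000 nM.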

Compound 3, concentration for total growth inhibition: 72400 nM
Estimate against measurement, compound 3: 1.4-fold (0.16 log units) below; measured number inside the range.
By their numbers in this assay, from the lowest: compound 2; then compounds 1 and 3 (each within the scatter of the next).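

In this assay, for the compounds shown here, replacing benzyl with 3-phenylpropyl on the aromatic nitrogen gives a 1.1-fold higher number from compound 1 to compound 3 (0.04 log units; within the scatter), the first comparison here in which only one part of the structure changes. Within the scatter, this longer chain carrying the same phenyl ring produces no readable change in growth inhibition, so the chain length at this position, across these two compounds, has no visible effect on the read-out. No measurement shown here offers an explanation for this result.

Going by these compounds, whether a different group on the chain, such as an amine or a carboxylic acid, or a much shorter chain such as methyl, would shift the number remains open. The compounds shown also leave unresolved which of the several differences in compound 2 accounts for its separation from compound 1.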